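Series notes: hydrazone aryl swap from compound 1 to compound 4

A few compounds are considered here, and "the series" means these few. Any claim that something is new, unique, unknown or untested is made for them only; others in the source may bear on it.

Compounds measured so far:
compound 2 `CCCSc1nc(N/N=C(\C)c2ccccc2O)c2nnn(Cc3ccco3)c2n1`: in a functional assay on ECa-109 cells (Homo sapiens) for antiproliferative activity, read by MTT assay, with a stated time of 72 h (a higher number here means a weaker inhibitor, a lower number a stronger inhibitor), compound 2 gives 5760 nM.
compound 3 `CCCSc1nc(N/N=C(\C)c2ccccc2O)c2nnn(Cc3cccc(Cl)c3)c2n1`: in this assay compound 3 gives 13000 nM.
compound 1 `CCCSc1nc(N/N=C(\C)c2ccc(OC)cc2)c2nnn(Cc3ccccc3)c2n1`: in this assay compound 1 reaches only the assay limit, > 64000 nM.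

Compound 1 thus stands at the limit of > 64000 nM in this assay, at which 1 of the 3 values shown sits, with no number of its own. For the measured compounds named here, the one measured step, a 2.3-fold higher number from compound 2 to compound 3 (0.35 log units; beyond the scatter), alters the group on the saturated chain carbon bound to an aromatic nitrogen and leaves the hydrazone aryl untouched. Going by the values given here, the change to compound 4 `CCCSc1nc(N/N=C(\C)c2ccc(Br)cc2)c2nnn(Cc3ccccc3)c2n1` is bromo in place of methoxy on an aromatic carbon, 4-methoxyphenyl to 4-bromophenyl; no measured step covers this part of the molecule, so neither direction nor size can be read from compounds 1 to 3. Starting from a limit, the estimate for compound 4 is 30000 nM with a range of 8000 nM to 90000 nM, corresponding to an expected step of an at least 2.1-fold lower number from compound 1 to compound 4 (0.32 log units; beyond the scatter).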

Compound 4, half-maximal inhibitory concentration: 4670 nM
Beside the measured number, compound 4's estimate is 6.4-fold (0.81 log units) above it; the measured number lies below the stated range.
By their numbers in this assay, from the lowest: compounds 4 and 2 (each within the scatter of the next); then compound 3. At a limit, above all of these: compound 1.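

The hydrazone aryl now has a measured step in this assay: an at least 13-fold lower number from compound 1 to compound 4 (1.13 log units; beyond the scatter), with bromo in place of methoxy on an aromatic carbon and the rest of the molecule unchanged. This position can therefore shift the read-out by more than the group on the saturated chain carbon did in a 2.3-fold higher number from compound 2 to compound 3 (0.35 log units; beyond the scatter). The larger step is only a floor, as compound 1 stands at a limit: the limit of > 64000 nM in this assay, at which 1 of the 4 values shown sits.

From the compounds shown here alone, whether the step follows from bromo entering or methoxy leaving stays open; an unsubstituted phenyl, a fluoro or an amine at this place would separate the two. Also open, going by these compounds, is whether the same change holds with furan-2-yl on the chain carbon.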